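Swapping a Ring Amine for a Chain Amine

This account rests on a few compounds, and the source may have more. Where it says the series, first, only, none or still open, it means among the compounds named here.

Measured so far:
compound 1 `O=C1C(NC2CCCC2)=CC(=O)c2c1nc1n2[C@H]2OC[C@@H](O)[C@H]2OC1`: > 16000 nM
compound 2 `O=C1C=C(Nc2cccc(Cl)c2)C(=O)c2c1nc1n2[C@H]2OC[C@@H](O)[C@H]2OC1`: 4720 nM

The two measured compounds share one core and differ only in the amine attached to it. In a functional assay on MCF7 cells (Homo sapiens) for inhibition, read by sulforhodamine B assay (a higher number here means a weaker inhibitor, a lower number a stronger inhibitor), compound 2 gives 4720 nM. On these data alone, for compound 1 the outcome in this assay is a limit of the assay and not a number, > 16000 nM, so its exact potency is unknown. Compound 1 sits at the limit of > 16000 nM in this assay, at which 1 of the 2 values shown sits, which places it as the weaker of the two as far as the numbers can tell.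

Compound 3 `CCCN(CCC)C1=CC(=O)c2c(nc3n2[C@H]2OC[C@@H](O)[C@H]2OC3)C1=O` is the next compound to be tested. Compared with compound 1 it carries dipropylamino in place of cyclopentylamino on a double-bonded ring carbon. Among the measured compounds shown here, no measured pair isolates this kind of change, so no direction can be read from the data. Since compound 1 already sits at a limit, the step that the limit leaves unreadable from compound 1 to compound 3 is expected to be small and within the scatter, in no clear direction. Compound 3 is therefore expected to give about 20000 nM, within a range from 6000 nM to 60000 nM, and a limit rather than a number may well be reported again.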

Compound 3, half-maximal inhibitory concentration: > 16000 nM
Compound 3: only a limit was reported (the forecaster's own chance of this, stated with the estimate: 65%); the middle value lies beyond the limit too.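

In this assay compound 3 gives > 16000 nM, which is a limit of the assay and not a number. Compound 1 also gives only a limit, > 16000 nM, and no step can be read between compound 1 and compound 3. The compounds shown leave open whether dipropylamino in place of cyclopentylamino changes potency at all.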